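The source may report more compounds than this note shows. Statements on the series, on what has been measured and on what is new or still open speak of the compounds shown alone.

Measured compounds, with their values in a functional assay on PC-3 cells (Homo sapiens) for cytotoxicity, read by MTT assay, with a stated time of 72 h; on this read-out lower numbers stand for stronger inhibition and higher numbers for weaker inhibition:
- compound 1, `[O-][n+]1nc(NCOCc2ccc(C(F)(F)F)cc2)[n+]([O-])c2ccccc21`: 9310 nM
- compound 2, `CCCCOCNc1n[n+]([O-])c2ccccc2[n+]1[O-]`: 6010 nM
- compound 3, `[O-][n+]1nc(NCOCc2ccccc2)[n+]([O-])c2ccccc21`: 11900 nM

Compound 3 gives the highest of the three numbers in this assay, but neither neighbour lies outside the usual scatter: compound 1 sits close, a 1.3-fold higher number from compound 1 to compound 3 (0.11 log units; within the scatter), and compound 2 a little further, a 2.0-fold higher number from compound 2 to compound 3 (0.30 log units; within the scatter). On these numbers the three compounds are not separated.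

Compound 4, `O=[N+]([O-])c1cccc(COCNc2n[n+]([O-])c3ccccc3[n+]2[O-])c1`, is the next compound of the set. It differs from compound 3 in one place: nitro in place of hydrogen on an aromatic carbon. Going by the values given here, of the measured steps, only the one from compound 1 to compound 3 speaks to a substituent on this phenyl ring, and it was within the scatter: a 1.3-fold higher number from compound 1 to compound 3 (0.11 log units; within the scatter). The step from compound 2 to compound 3, a 2.0-fold higher number from compound 2 to compound 3 (0.30 log units; within the scatter), changes a different part of the molecule and says little here. Nothing measured suggests that decorating the phenyl ring moves the number beyond the scatter, so no step beyond the scatter is expected in this assay, in either direction, and the estimated step is a 1.2-fold lower number from compound 3 to compound 4 (0.08 log units; within the scatter). Compound 4 is therefore expected to give about 10000 nM, with a likely range from 4000 nM to 25000 nM.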

Compound 4, half-maximal inhibitory concentration: > 100000 nM
Compound 4: a limit, no number (the forecaster's own chance of this, stated with the estimate: 5%); middle value at least 10-fold (1.00 log units) from the limit.
By their numbers in this assay, from the lowest: compounds 2, 1 and 3 (each within the scatter of the next). At a limit, above all of these: compound 4.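

In this assay compound 4 gives > 100000 nM, which is a limit of the assay and not a number. Putting nitro on the phenyl ring, meta to a large group, gives an at least 8.4-fold higher number from compound 3 to compound 4 (0.92 log units; beyond the scatter), so this ring is not a part of the molecule where any added group leaves the number unchanged, as the earlier trifluoromethyl change, a 1.3-fold higher number from compound 1 to compound 3 (0.11 log units; within the scatter), taken alone might have suggested. From the compounds shown here alone, the new step marks only the smallest size this change can have, and its full size stays unknown: the limit of > 100000 nM in this assay, at which 1 of the 4 values shown sits.

The compounds shown do not tell whether the weaker result belongs to nitro itself or to the carbon it occupies, as compound 1 and compound 4 differ in the group on the ring and in where it sits. An amine or a methoxy group on that same carbon, or nitro moved to another carbon of the ring, would help separate these two readings.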